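The source may hold more compounds than are shown below. What is called first, only, known or untested is meant among the compounds shown, and "the series" means these compounds.

Measured compounds:
Compound 1, `Nc1cc(N)c2nc(-c3ccccc3)c(NCc3ccc(Cl)c(Cl)c3)nc2c1`: 70800 nM.
Compound 2, `COc1cc(CNc2nc3cc(N)cc(N)c3nc2-c2ccccc2)cc(OC)c1OC`: < 50200 nM, a limit of the assay rather than a number.
Compound 3, `CCOC(=O)[C@H](CCC(=O)O)NC(=O)c1ccc(Oc2nc3cc(N)cc(N)c3nc2-c2ccccc2)cc1`: < 50200 nM, also a limit of the assay rather than a number.

All three were tested in a functional assay on 786-0 cells (Homo sapiens) for inhibition, read by sulforhodamine B assay, with a stated time of 48 h; on this read-out lower numbers stand for higher toxicity in this test and higher numbers for lower toxicity in this test. Compound 1 gives 70800 nM, the only result in this assay that is an actual number. For compound 2 the result is < 50200 nM, which is a limit of the assay. For compound 3 the result is < 50200 nM, again a limit of the assay. Compound 1 therefore cannot be ranked against the other two; what the data show is the limit of < 50200 nM in this assay, at which 2 of the 3 values shown sit.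

The compound still to be measured is compound 4, `Nc1cc(N)c2nc(-c3ccccc3)c(NCc3ccc(F)cc3)nc2c1`. It differs from compound 1 in a single place: 4-fluorophenyl in place of 3,4-dichlorophenyl on a saturated chain carbon bound to a nitrogen on an aromatic ring. The shared core of compound 1 is untouched. Going by the values given here, no pair of measured compounds differs in one place, so there is no measured step to compare this change with. The change sits at the outer end of the benzyl arm, and no step beyond the usual scatter is expected from it. Compound 4 is accordingly expected to give about 80000 nM, in the range 35000 nM to 160000 nM. This expectation amounts to a step of a 1.1-fold higher number from compound 1 to compound 4 (0.05 log units; within the scatter), within the usual scatter.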

Compound 4, concentration lethal to 50% of the cells: < 100000 nM
Compound 4 ended at the assay's limit; the forecaster's own chance of this, stated with the estimate: 30%; the middle value lies beyond the limit too.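

In this assay compound 4 gives < 100000 nM, which is a limit of the assay and not a number. The step between compound 1 and compound 4 therefore cannot be read. The compounds shown leave open whether 4-fluorophenyl in place of 3,4-dichlorophenyl changes the toxicity in this test at all, and in which direction.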